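This account rests on a few compounds, and the source may have more. Where it says the series, first, only, none or still open, it means among the compounds named here.

The series shares one core, seen in compound 1 `CSC1(C)C(=O)N(c2ccccc2)c2ncccc21`, compound 2 `CC1(C)C(=O)N(Cc2ccccc2)c2ncccc21` and compound 3 `COCCSC1(C)C(=O)N(c2ccccc2)c2ncccc21`. Among the compounds with values here, in a functional assay on the whole organism (Pleural cavity) for inhibition, with Rattus norvegicus as the target, at a dose of 25 mg/kg (on this read-out higher numbers stand for more inhibition at the one dose given (going by the name of the read-out) and lower numbers for less inhibition), compound 1 gives 34% and compound 3 gives 26%; the one measured step between them, a number 8 percentage points lower from compound 1 to compound 3 (within the scatter), is a change on a saturated chain carbon bound to a sulfur. Compound 2 carries a benzyl on the amide nitrogen where compound 1 carries a phenyl. In this assay compound 2 gives 12%, the lowest of the three numbers, with compound 3 the nearest and compound 1 the furthest, both beyond the scatter.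

Compound 4 `CC1(C)C(=O)N(Cc2ccc(Cl)cc2)c2ncccc21` is the unmeasured compound. It differs from compound 2 in one place: chloro in place of hydrogen on an aromatic carbon. No measured step in this set touches an aromatic carbon of that ring, so nothing shown bears directly on this change; the only step known, from compound 1 to compound 3, lies within the scatter and concerns a different part of the molecule. On this footing, no step beyond the scatter is expected from compound 2 to compound 4, and the estimated change is a number 4 percentage points higher from compound 2 to compound 4 (within the scatter). Compound 4 is therefore expected to give about 16% in this assay, with a range from 0% to 36%.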

Compound 4, a percentage reported as inhibition, in the whole organism at one dose (the size of the read-out at that dose, not a potency): 6%
Estimate against measurement, compound 4: 10 percentage points above, within the range that was stated.
By their numbers in this assay, from the lowest: compounds 4 and 2 (each within the scatter of the next); then compounds 3 and 1 (each within the scatter of the next).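

In this assay, within the data shown here, the first change on an aromatic carbon of the benzyl ring gives a number 6 percentage points lower from compound 2 to compound 4 (within the scatter) and so stays within the scatter. For chloro in place of hydrogen, on this six-membered aromatic ring of carbon only and para to a large group, the data therefore show no measurable change at this one dose, and compound 2 and compound 4 cannot be told apart. No measurement shown here explains this outcome.

The compounds shown leave open whether a different group at this same place, such as an amine or a carboxylic acid, would give a step beyond the scatter. They also leave open whether chloro would behave in the same way on the phenyl ring of compound 1, which carries that ring directly on the amide nitrogen and has a different group on the saturated carbon of the core.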